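This account rests on a few compounds, and the source may have more. Where it says the series, first, only, none or still open, it means among the compounds named here.

In a functional assay on Flp-In T-REx293 cells for antagonist activity at Free fatty acid receptor 1 (Homo sapiens), read by calcium flux (on this read-out higher numbers stand for weaker inhibition and lower numbers for stronger inhibition), compound 1 `Cc1cccc(Oc2cc(F)cc(N3Cc4ccccc4S3(=O)=O)c2)c1` gives 25100 nM. Compound 2 `N#Cc1ccccc1Oc1cc(F)cc(N2Cc3ccccc3S2(=O)=O)c1` returns only a limit of this assay, > 100000 nM. Compound 2 thus sits at the limit of > 100000 nM in this assay, at which 1 of the 2 values shown sits, so its standing is known only as a bound. Among the measured compounds shown here, the step of an at least 3.9-fold higher number from compound 1 to compound 2 (0.60 log units; beyond the scatter) is the sole measured change at that oxygen. Compound 3 `O=S1(=O)c2ccccc2CN1c1cc(F)cc(Oc2ccccn2)c1` differs from compound 2 by pyridin-2-yl in place of 2-cyanophenyl on an oxygen on an aromatic ring. For the measured compounds named here, no measured step covers this exchange, and the one step bearing on the site points toward weaker inhibition, so compound 3 is expected near the limit, at an estimated 100000 nM with a range of 40000 nM to 300000 nM, a step of a number no higher from compound 2 to compound 3 (the limit leaves the size open).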

Compound 3, half-maximal inhibitory concentration: > 100000 nM
Compound 3 gave a limit, no number; the forecaster's own chance of this, stated with the estimate: 60%; the middle value lies on the limit itself.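

In this assay compound 3 also returns only a limit of the assay, > 100000 nM. Pyridin-2-yl in place of 3-methylphenyl on the oxygen gives an at least 3.9-fold higher number from compound 1 to compound 3 (0.60 log units; beyond the scatter), so a second group at this position falls short of the 3-methylphenyl of compound 1. The step between compound 2 and compound 3 cannot be read, as both values are limits, and the series now gathers at the edge of the assay: the limit of > 100000 nM in this assay, at which 2 of the 3 values shown sit.

Going by these compounds, how far compound 2 and compound 3 actually lie apart stays open. So does whether a phenyl ring carrying an amine or a carboxylic acid on that oxygen would inhibit more strongly than compound 1.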